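This account rests on a few compounds, and the source may have more. Where it says the series, first, only, none or still open, it means among the compounds named here.

Measured so far in a functional assay (Homo sapiens) for inhibition; a lower number here means a stronger inhibitor, a higher number a weaker inhibitor:
- compound 1 `COc1cc(/C=C/C(=O)c2ccc([N+](=O)[O-])cc2)cc(OC)c1`: 20000 nM
- compound 2 `C=CCOc1ccc(C(=O)/C=C/c2cc(OC)cc(OC)c2)cc1`: 25000 nM
- compound 3 `COc1cc(/C=C/C(=O)c2ccccc2O)cc(OC)c1`: 8100 nM

Compound 3 at 8100 nM has the lowest number of the three, and its gap to each of the other two lies beyond the scatter. The next structure is compound 4 `COc1cc(/C=C/C(=O)c2ccc(O)cc2)cc(OC)c1`, reached by the change 4-hydroxyphenyl in place of 2-hydroxyphenyl on a carbonyl carbon which reads as 4-hydroxyphenyl in place of 2-hydroxyphenyl on a carbonyl carbon. Going by the values given here, only one measured step is available, a 1.3-fold higher number from compound 1 to compound 2 (0.10 log units; within the scatter), and it exchanges other groups, so it bears on this move only indirectly. Among the compounds with values here, no measured pair isolates the move itself. Compound 3 alone carries the 2-hydroxyphenyl group, and it alone stands apart in number. Compound 4 gives up that group, so a drift is expected toward compound 1 at 20000 nM and compound 2 at 25000 nM in this assay as the nearest reference points. With three values behind it, this expectation stays loose. The expected move is a 2.1-fold higher number from compound 3 to compound 4 (0.32 log units; beyond the scatter), a modest step to a higher number by estimate. For compound 4 the estimate is 17000 nM, with an expected range from 7000 nM to 40000 nM.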

Compound 4, half-maximal inhibitory concentration: 14000 nM
For compound 4 the middle estimate is 1.2-fold (0.08 log units) above the measured one; the range from low to high includes it.
By their numbers in this assay, from the lowest: compounds 3, 4, 1 and 2 (each within the scatter of the next, the first and the last beyond it).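

In this assay the hydroxy group changes place with a 1.7-fold higher number from compound 3 to compound 4 (0.24 log units; within the scatter) within the scatter, so this pair gives no readable preference between 2-hydroxyphenyl and 4-hydroxyphenyl on the carbonyl carbon. Compound 3 differs beyond the scatter from compound 1 and compound 2, but the two further steps, a 1.4-fold lower number from compound 1 to compound 4 (0.15 log units; within the scatter) and a 1.8-fold lower number from compound 2 to compound 4 (0.25 log units; within the scatter) also lie within the scatter, so compound 4 cannot be ordered against any of the other three and sits as a bridge across that gap. The separation of compound 3 therefore holds only against the nitro and allyloxy compounds and does not amount to a clear effect of moving the hydroxy group, while exchanging nitro for hydroxy and removing the allyl from the oxygen both leave the number inside the scatter.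

Going by these compounds, whether an amine or a carboxylic acid in place of the hydroxy group of compound 4, or a longer chain than allyl on that oxygen, would give a step beyond the scatter stays open. Nothing available speaks to the reason for any of these values.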